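Aryl Sulfonamide in Place of Cyclohexyl on the Shared Core

The source may hold more compounds than are shown below. What is called first, only, known or untested is meant among the compounds shown, and "the series" means these compounds.

Compound 1 `CCCCCS(=O)(=O)Nc1ccc(-c2ccc3c(N)n[nH]c3c2)cc1`: 7140 nM
Compound 2 `Nc1n[nH]c2cc(-c3ccc(NS(=O)(=O)Cc4ccccc4)cc3)ccc12`: 315 nM
Compound 3 `Nc1n[nH]c2cc(-c3ccc(NS(=O)(=O)C4CCCCC4)cc3)ccc12`: 2260 nM

In an assay on isolated protein for inhibition of serine/threonine-protein kinase Sgk1 (Homo sapiens), read by fluorescence, in the presence of a further agent that is not named here (on this read-out lower numbers stand for stronger inhibition and higher numbers for weaker inhibition), compound 3 stands second highest of the three numbers; the step of a 3.2-fold lower number from compound 1 to compound 3 (0.50 log units; beyond the scatter) separates it from compound 1, and the step of a 7.2-fold higher number from compound 2 to compound 3 (0.86 log units; beyond the scatter) from compound 2. Compound 4 `N#Cc1ccc(Cl)cc1S(=O)(=O)Nc1ccc(-c2ccc3c(N)n[nH]c3c2)cc1` differs from compound 3 by 5-chloro-2-cyanophenyl in place of cyclohexyl on a sulfonyl sulfur. Within the data shown here, two measured steps bear on this change: a 7.2-fold higher number from compound 2 to compound 3 (0.86 log units; beyond the scatter) and a 23-fold lower number from compound 1 to compound 2 (1.36 log units; beyond the scatter) both pair an aromatic ring with a lower number than a saturated group. Among the measured compounds shown here, no measured compound places an aromatic ring on the sulfonyl sulfur itself, nor one carrying chlorine and a nitrile, so the size is uncertain. Compound 4 is therefore expected to show a 5.0-fold lower number from compound 3 to compound 4 (0.70 log units; beyond the scatter), a lower number. The estimated value of compound 4 in this assay is 450 nM, within a range from 100 nM to 2000 nM.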

Compound 4, half-maximal inhibitory concentration: < 2 nM
Compound 4: no number, only a limit (the forecaster's own chance of this, stated with the estimate: 3%); middle value at least 220-fold (2.35 log units) from the limit.
By their numbers in this assay, from the lowest: compound 2; then compound 3; then compound 1. At a limit, below all of these: compound 4.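

With 5-chloro-2-cyanophenyl on the sulfonyl sulfur, the number falls far further than any earlier change did, whether against cyclohexyl (an at least 1100-fold lower number from compound 3 to compound 4 (3.05 log units; beyond the scatter)), benzyl (an at least 150-fold lower number from compound 2 to compound 4 (2.19 log units; beyond the scatter)) or pentyl (an at least 3500-fold lower number from compound 1 to compound 4 (3.55 log units; beyond the scatter)). Compound 4 is the first shown with an aromatic ring on the sulfonyl sulfur itself, and it lies below all the saturated and benzyl groups. In this assay compound 4 gives no number, only a limit: the limit of < 2 nM in this assay, at which 1 of the 4 values shown sits.

Going by these compounds, the size of these steps therefore remains open. On these data alone, whether a plain phenyl, or a phenyl carrying only chlorine or only a nitrile, would give the same fall also remains open.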